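Compound 1 to compound 4: chloro exchanged for hydroxy

This account rests on a few compounds, and the source may have more. Where it says the series, first, only, none or still open, it means among the compounds named here.

- compound 1 `C#CCSc1nc(Nc2ccc(Cl)cc2)c2ccncc2n1` gives 16400 nM
- compound 2 `C#CCSc1nc(Nc2ccc(Cl)cc2Cl)c2ccncc2n1` gives 25500 nM
- compound 3 `C#CCSc1nc(Nc2cc(OC)c(OC)c(OC)c2)c2ccncc2n1` gives 5680 nM

All three values come from a functional assay on MGC-803 cells (Homo sapiens) for inhibition, read by MTT assay, with a stated time of 72 h; a higher number here means a weaker inhibitor, a lower number a stronger inhibitor. Compound 1 at 16400 nM is level, within the scatter, with compound 2 at 25500 nM. Compound 3 at 5680 nM gives a lower number, beyond the scatter from compound 1.

The change to compound 4 `C#CCSc1nc(Nc2ccc(O)cc2)c2ccncc2n1` puts hydroxy in place of chloro on an aromatic carbon, para to a large group: hydroxy in place of chloro on an aromatic carbon. Among the compounds with values here, no measured step makes this exchange. The nearest evidence is a 1.6-fold higher number from compound 1 to compound 2 (0.19 log units; within the scatter), which adds a chloro and leaves the number within the scatter. That step says little about removing chloro, and it gives no sign of a large effect. Compound 3 at 5680 nM shows that a compound with oxygen-bearing groups on this ring can reach a lower number, but it differs from compound 1 in more than one place, so it supports only a slight lean downward.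

The expected result is a small move to a lower number, possibly no move beyond the scatter: a 1.6-fold lower number from compound 1 to compound 4 (0.21 log units; within the scatter). For compound 4 the estimated value is 10000 nM, with an expected range from 3500 nM to 30000 nM.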

Compound 4, half-maximal inhibitory concentration: > 80000 nM
Compound 4: no number, only a limit; the forecaster's own chance of this, stated with the estimate: 8%; middle value at least 8.0-fold (0.90 log units) away from the limit.
By their numbers in this assay, from the lowest: compound 3; then compounds 1 and 2 (each within the scatter of the next). At a limit, above all of these: compound 4.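

In this assay, hydroxy in place of chloro on an aromatic carbon, para to a large group, gives an at least 4.8-fold higher number from compound 1 to compound 4 (0.68 log units; beyond the scatter). Within the data shown here, the only earlier one-place step, a 1.6-fold higher number from compound 1 to compound 2 (0.19 log units; within the scatter), stays within the scatter, so this is the first single change that moves the number beyond it, and the move is toward a weaker inhibitor. The position therefore does not accept every small exchange: one heavy atom replaces one heavy atom here, and the hydroxy brings a hydrogen-bond donor and a hydrogen-bond acceptor that the chloro does not count, though the data cannot tell whether those counts are what matters.

Still open, as far as these compounds go, is whether an amine or a carboxylic acid at this same position, as a 4-aminophenyl or 4-carboxyphenyl in place of the 4-chlorophenyl, would read like compound 1 or like compound 4. From the compounds shown here alone, the full size of the step also stays open, because compound 4 carries a limit and not a number: the limit of > 80000 nM in this assay, at which 1 of the 4 values shown sits.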